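The compounds below may be only part of what the source reports. "The series", "measured", "known", "first", "only" and "open" are said of these compounds alone.

Measured compounds:
compound 1, `Clc1[nH]ccc2ncnc1-2`: < 5%
compound 2, `[N-]=[N+]=Nc1nccc2c1ncn2C1O[C@H](CO)[C@@H](O)[C@H]1O`: < 5%

In a functional assay on EL4 cells (Mus musculus) for inhibition, tested at 100 uM (a lower number here means less inhibition, a higher number more inhibition at the concentration tested (going by the name of the read-out)), compound 1 gives < 5%, which is a limit of the assay rather than a number. Compound 2 likewise gives < 5% in this assay, again a limit. Compound 1 therefore stands at the floor of what is shown: the limit of < 5% in this assay, at which 2 of the 2 values shown sit, and no measured value here separates it from compound 2.

The next compound, compound 3, `CCNc1[nH]ccc2ncnc1-2`, keeps the core of compound 1 and differs in one place: ethylamino in place of chloro on an aromatic carbon. No measured step of this kind is available, so nothing shown points to inhibition rising or falling in this assay; the expectation is a step of no size beyond the scatter, with compound 3 most likely remaining at the limit as compound 1 does. Compound 3 is thus expected to give 5%, within 0% to 20%. The estimated step of a number no lower from compound 1 to compound 3 (the limit leaves the size open) is expected to stay inside the usual scatter.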

Compound 3, a percentage reported as inhibition, at one concentration (the size of the read-out at that concentration, not a potency): < 5%
Compound 3: a limit, no number; the forecaster's own chance of this, stated with the estimate: 60%; the middle value lies on the limit itself.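

In this assay compound 3 gives < 5%, a limit of the assay, so the step from compound 1 to compound 3 cannot be read, and the compounds shown all sit at one floor: the limit of < 5% in this assay, at which 3 of the 3 values shown sit.

The compounds shown leave open whether any change to the shared core lifts inhibition clear of this limit.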